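Adding a cyclopropyl to compound 1

The compounds below may be only part of what the source reports. "The series", "measured", "known", "first", "only" and "open" are said of these compounds alone.

- compound 1 `O=C1COc2ccc(-c3cccc(NS(=O)(=O)c4ccc(F)cc4)c3)cc2N1`: 18300 nM
- compound 2 `O=C1COc2ccc(-c3cnc4ccccc4c3)cc2N1C1CCCCC1`: > 40000 nM (a limit, not a number)

Among the measured compounds shown here, in a functional assay on MCF7 cells (Homo sapiens) for antiproliferative activity, read by MTT assay, with a stated time of 72 h (on this read-out lower numbers stand for stronger inhibition and higher numbers for weaker inhibition), compound 1 gives 18300 nM, the only true number so far. Compound 2 reached only a limit, > 40000 nM. Compound 3 `O=C1COc2ccc(-c3cccc(NS(=O)(=O)c4ccc(F)cc4)c3)cc2N1C1CC1` keeps the core of compound 1 and makes one change: cyclopropyl in place of hydrogen on an amide-type nitrogen in a ring. For the measured compounds named here, no measured pair shows this change, so only a modest shift in this assay is expected, leaning toward stronger inhibition. The expected move is a 1.5-fold lower number from compound 1 to compound 3 (0.18 log units; within the scatter). Compound 3 is estimated at 12000 nM, within an estimated range of 3500 nM to 40000 nM.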

Compound 3, half-maximal inhibitory concentration: > 40000 nM
Compound 3 gave a limit, no number (the forecaster's own chance of this, stated with the estimate: 15%); middle value at least 3.3-fold (0.52 log units) from the limit.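

Among the compounds shown here, until now, no pair showed what a group on this amide-type nitrogen in a ring does while the rest of compound 1 stays the same. In this assay, cyclopropyl in place of hydrogen gives an at least 2.1-fold higher number from compound 1 to compound 3 (0.33 log units; beyond the scatter), so inhibition weakens rather than strengthens. The reading for compound 3 is a limit, not a number, so the step gives only a minimum size: the limit of > 40000 nM in this assay, at which 2 of the 3 values shown sit.

The compounds shown leave open whether any group on this nitrogen weakens inhibition or only cyclopropyl does. A methyl, or a longer chain carrying an amine, could separate the two.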